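Cyano for Trifluoromethyl on a Pyridyl Enone Scaffold

A few compounds are considered here, and "the series" means these few. Any claim that something is new, unique, unknown or untested is made for them only; others in the source may bear on it.

Measured so far:
compound 1, `O=C(/C=C/c1ccncc1)c1cccc(C(F)(F)F)c1`, 41000 nM
compound 2, `O=c1cc(-c2cccnc2)oc2ccccc12`, about 100000 nM
compound 3, `O=C(/C=C/c1ccncc1)c1ccco1`, 50000 nM

In a functional assay with Rattus norvegicus as the target (a higher number here means a weaker inhibitor, a lower number a stronger inhibitor), compound 1 gives 41000 nM, the lowest of the numbers shown so far. Compound 3 gives 50000 nM in this assay, and the two sit within the usual scatter of each other, so nothing separates them. Compound 2, in this assay, gives about 100000 nM, a gap from compound 1 that lies beyond the scatter.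

Compound 4 is `N#Cc1cccc(C(=O)/C=C/c2ccncc2)c1`. It differs from compound 1 by cyano in place of trifluoromethyl on an aromatic carbon. Going by the values given here, no pair of measured compounds shows what such an exchange does here. With all three measured values lying in a narrow band, nothing in the data points to a large move in either direction, so the expectation is a step small enough to stay within the scatter, in either direction. The estimate for compound 4 is therefore 40000 nM, with a range from 15000 nM to 110000 nM, which is expected to amount to a step of a 1.0-fold lower number from compound 1 to compound 4 (0.01 log units; within the scatter).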

Compound 4, half-maximal inhibitory concentration: 85000 nM
Beside the measured number, compound 4's estimate is 2.1-fold (0.33 log units) below it; the measured number falls inside the stated range.
By their numbers in this assay, from the lowest: compounds 1, 3, 4 and 2 (each within the scatter of the next, the first and the last beyond it).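

Going by these compounds alone, this is the first exchange at this position that can be read in this assay: cyano in place of trifluoromethyl on an aromatic carbon, meta to a large group, gives a 2.1-fold higher number from compound 1 to compound 4 (0.32 log units; beyond the scatter) and so shows that the position is not indifferent to the group it carries. The step is modest, but it runs toward a weaker inhibitor, which makes trifluoromethyl the better of the two groups compared on this core. Nothing available on the compounds accounts for this difference.

On these data alone, with a single exchange at this carbon, it remains open whether a methoxy group, a chlorine atom or an amine there would match trifluoromethyl or fall closer to cyano. As far as these compounds go, it is equally open whether the same exchange at another carbon of the ring would give a step of similar size.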